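A few compounds are considered here, and "the series" means these few. Any claim that something is new, unique, unknown or untested is made for them only; others in the source may bear on it.

Values in an ADME assay on microsomes from liver (Rattus norvegicus) for metabolic stability; on this read-out lower numbers stand for a shorter-lived compound and higher numbers for a longer-lived compound:
- Compound 1 `CC(C)C(c1ccc(-c2ccc3cccc(F)c3c2)[nH]c1=O)C1NC(=O)NC1=O`: 0.145 h
- Compound 2 `CC(C)C(c1ccc(-c2ccc3cccc(F)c3c2)[nH]c1=O)C1SC(=O)NC1=O`: 0.76 h
- Compound 3 `CC(C)C(/C=C1\SC(=O)NC1=O)c1ccc(-c2ccc3cccc(F)c3c2)[nH]c1=O`: not yet measured

Among the measured compounds shown here, compound 2, at 0.76 h, holds the highest of the two numbers so far. Compound 3 differs from it by a group of 8 heavy atoms (4 carbon, 1 nitrogen, 2 oxygen, 1 sulfur; one five-membered non-aromatic ring with 2 hetero atoms) in place of a group of 7 heavy atoms (3 carbon, 1 nitrogen, 2 oxygen, 1 sulfur; one five-membered non-aromatic ring with 2 hetero atoms), on a saturated chain carbon bound to an aromatic carbon and a saturated chain carbon. For the measured compounds named here, the only measured step, a 5.2-fold higher number from compound 1 to compound 2 (0.72 log units; beyond the scatter), exchanges one ring group for another at this place. Going by the values given here, it is a loose guide, since no measured pair shows a change of this kind. Without such evidence, only a small change is expected in this assay, within the scatter and slightly downward if anything: a 1.3-fold lower number from compound 2 to compound 3 (0.10 log units; within the scatter). Compound 3 is estimated at 0.6 h, with an expected range of 0.2 h to 1.6 h.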

Compound 3, half-life: 2.62 h
Estimate against measurement, compound 3: 4.4-fold (0.64 log units) below; measured number above the stated range.
By their numbers in this assay, from the lowest: compound 1; then compound 2; then compound 3.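

In this assay this place tolerates more than an exchange of one ring for another: the group of 8 heavy atoms gives a 3.4-fold higher number from compound 2 to compound 3 (0.54 log units; beyond the scatter) on top of the earlier ring exchange. Measured against the 2,5-dioxoimidazolidin-4-yl group, the same group gives an 18-fold higher number from compound 1 to compound 3 (1.26 log units; beyond the scatter) and so sets the widest step in the series. No measured information accounts for either step.

Open, from the compounds shown here alone, is whether the double bond outside the ring is needed, or whether a saturated chain carrying the same ring would do as well. A carboxylic acid or an amine at this place also remains untested within the compounds shown.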